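Methyl on the Ring and Tolerated Concentration

A few compounds are considered here, and "the series" means these few. Any claim that something is new, unique, unknown or untested is made for them only; others in the source may bear on it.

Compound 2 `CC(C)Sc1nc(O)cc(C(C)c2c(F)cccc2F)n1` gives 167000 nM in a functional assay on MT4 cells (Homo sapiens) for cytotoxicity; a lower number here means that less compound is tolerated, a higher number that more compound is tolerated. Among the numbers shown it holds the highest, with compound 1 `CCC(c1cc(O)nc(SC(C)C)n1)c1c(F)cccc1F` nearest, giving 130000 nM in this assay, and the step of a 1.3-fold higher number from compound 1 to compound 2 (0.11 log units; within the scatter) stays within the scatter. For compound 3 `CC(C)CSc1nc(O)cc(C(C)c2c(F)cccc2F)n1` this assay reports a limit, > 200000 nM. The step of an at least 1.1-fold higher number from compound 2 to compound 3 (0.07 log units; that floor lies within the scatter) is given only as a floor because it runs into (the limit of > 200000 nM in this assay, at which 1 of the 3 values shown sits). Compound 4 `Cc1c(O)nc(SC(C)C)nc1C(C)c1c(F)cccc1F` differs from compound 2 by methyl in place of hydrogen on an aromatic carbon. Neither measured step, hydrogen in place of methyl on the chain nor isobutyl in place of isopropyl on a sulfur, moved the number beyond the scatter, so for compound 4 a similar outcome is expected, a 1.0-fold higher number from compound 2 to compound 4 (0.01 log units; within the scatter). Compound 4 is therefore estimated at 170000 nM, between 100000 nM and 200000 nM.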

Compound 4, half-maximal cytotoxic concentration: 200000 nM
For compound 4 the middle estimate is 1.2-fold (0.07 log units) below the measured one; low and high end bracket the measured number.
By their numbers in this assay, from the lowest: compounds 1, 2 and 4 (each within the scatter of the next).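

Going by these compounds alone, the first change on the aromatic ring itself, methyl in place of hydrogen on an aromatic carbon ortho to a hydroxy group, gives a 1.2-fold higher number from compound 2 to compound 4 (0.08 log units; within the scatter) in this assay. This position therefore accepts one added carbon with no shift that can be told from the scatter of repeated measurements. The value of compound 3 is a limit: the limit of > 200000 nM in this assay, at which 1 of the 4 values shown sits.

Going by these compounds, whether a longer chain at this position would move the number remains open. The same holds for an amine or a carboxylic acid there.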